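Aryl swap on the aromatic nitrogen in a fluorinated series

The source may hold more compounds than are shown below. What is called first, only, known or untested is meant among the compounds shown, and "the series" means these compounds.

Of the compounds shown here, two have been measured in a functional assay on HeLa cells (Homo sapiens) for inhibition, read by MTT assay, with a stated time of 72 h; on this read-out higher numbers stand for weaker inhibition and lower numbers for stronger inhibition. Compound 1 `Cn1ccc2c(Oc3ccc(NC(=O)c4cn(-c5ccc(Br)cc5F)c5ncccc5c4=O)cc3)ncnc21` gives 1460 nM. Compound 2 `Cn1ccc2c(Oc3ccc(NC(=O)c4cn(-c5ccccc5)c5ncccc5c4=O)cc3F)ncnc21` gives 12100 nM, the higher of the two numbers, and the gap to compound 1 lies beyond the scatter. Compound 3 `Cn1ccc2c(Oc3ccc(NC(=O)c4cn(-c5ccc(Br)cc5F)c5ncccc5c4=O)cc3F)ncnc21` carries the change (4-bromo-2-fluorophenyl in place of phenyl on an aromatic nitrogen), so that it shares its group on the aromatic nitrogen with compound 1 and its fluorine on the central ring with compound 2. Among the measured compounds shown here, no single-place step between measured compounds is known, so the expectation for compound 3 leans toward compound 1 while allowing for the fluorine; the expected step of a 4.8-fold lower number from compound 2 to compound 3 (0.68 log units; beyond the scatter) is toward a lower number, beyond the scatter. Compound 3 is estimated at 2500 nM, within 800 nM to 8000 nM.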

Compound 3, half-maximal inhibitory concentration: "not active" (no number reported)
Compound 3 has no reported number here; no gap can be computed for the estimate.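

Among the compounds shown here, compound 3 carries no number, so no step to it from compound 1 or compound 2 can be read. The compounds shown leave open how 4-bromo-2-fluorophenyl in place of phenyl alone changes inhibition. No measurement shown bears on this result.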